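The source may report more compounds than this note shows. Statements on the series, on what has been measured and on what is new or still open speak of the compounds shown alone.

Measured compounds:
- compound 1, `CC/C(=C(/c1ccc(/C=C/C(=O)O)cc1)c1ccc2[nH]ncc2c1)c1ccccc1`, in a functional assay on MCF7 cells (Homo sapiens) for cytotoxicity, read by CellTiter-Glo, with a stated time of 5 days (a higher number here means a weaker inhibitor, a lower number a stronger inhibitor), gives 7.2 nM
- compound 2, `CCCC/C(=C(/c1ccc(/C=C/C(=O)O)cc1)c1ccc2[nH]ncc2c1)c1ccccc1`, gives 10 nM
- compound 3, `COC/C(=C(/c1ccc(/C=C/C(=O)O)cc1)c1ccc2[nH]ncc2c1)c1ccccc1`, gives 88 nM

Compound 1 has the lowest number of the three. Compound 2 sits nearest to it, with a 1.4-fold higher number from compound 1 to compound 2 (0.14 log units; within the scatter), while compound 3 lies furthest away, with a 12-fold higher number from compound 1 to compound 3 (1.09 log units; beyond the scatter). Between compound 2 and compound 3 the change is an 8.8-fold higher number from compound 2 to compound 3 (0.94 log units; beyond the scatter).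

Compound 4, `CC/C(=C(/c1ccc(/C=C/C(=O)O)cc1)c1ccc2[nH]nc(C)c2c1)c1ccccc1`, differs from compound 1 by methyl in place of hydrogen on an aromatic carbon. Among the compounds with values here, none of the measured steps touches this part of the molecule: the step from compound 1 to compound 2 and the two steps leading to compound 3 all alter the saturated chain attached to the double-bonded carbon, and the step to compound 2 stayed within the scatter while those to compound 3 went beyond it. Within the data shown here, there is thus no direct precedent for a change on the fused ring. On that basis compound 4 is expected to stay close to compound 1, with a 1.4-fold higher number from compound 1 to compound 4 (0.14 log units; within the scatter) not clearly beyond the scatter. Compound 4 is estimated at 10 nM, in a range from 3 nM to 35 nM.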

Compound 4, half-maximal inhibitory concentration: > 1000 nM
Compound 4: a limit, no number; the forecaster's own chance of this, stated with the estimate: 0%; middle value at least 100-fold (2.00 log units) away from the limit.
By their numbers in this assay, from the lowest: compounds 1 and 2 (each within the scatter of the next); then compound 3. At a limit, above all of these: compound 4.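

In this assay compound 4 stands at a limit and not at a number: the limit of > 1000 nM in this assay, at which 1 of the 4 values shown sits.

Even so, the step can be read as an at least 130-fold higher number from compound 1 to compound 4 (2.14 log units; beyond the scatter), so a methyl in place of hydrogen, a change of 1 heavy atom, is enough to carry the compound out of the measured range. The earlier compounds shown here varied only the saturated chain, where the largest step was a 12-fold higher number from compound 1 to compound 3 (1.09 log units; beyond the scatter), and they gave no sign that this aromatic carbon next to the ring nitrogen would respond so strongly.

Whether the loss is specific to methyl stays open, since the compounds shown carry no fluorine, chlorine, amine or ethyl group on this carbon. They also leave open whether the same methyl would act alike on the butyl-bearing or methoxy-bearing chains of compound 2 and compound 3.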